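The source may hold more compounds than are shown below. What is called first, only, known or untested is meant among the compounds shown, and "the series" means these compounds.

Working notes on the series.

The series rests on compound 1, `C=C(CCCC)C(=O)c1ccc(OCC(=O)O)c(C)c1C`, which in a functional assay on HL-60 cells (Homo sapiens) for antiproliferative activity, with a stated time of 72 h (a higher number here means a weaker inhibitor of growth, a lower number a stronger inhibitor of growth), gives 14400 nM. Compound 2, `C=C(CCCC)C(=O)c1ccc(OCC(=O)OC)c(C)c1C`, carries the change methyl in place of hydrogen on an oxygen next to a carbonyl group and in this assay gives 8600 nM; the measured step is a 1.7-fold lower number from compound 1 to compound 2 (0.22 log units; within the scatter).

Compound 3, `C=C(CCC)C(=O)c1ccc(OCC(=O)O)c(C)c1C`, differs from compound 1 in the core by hydrogen in place of methyl on a saturated chain carbon, three bonds along the chain from a double-bonded chain carbon. In this assay compound 3 gives 19300 nM; the step here is a 1.3-fold higher number from compound 1 to compound 3 (0.13 log units; within the scatter). Within the data shown here, no step between compound 2 and compound 3 is worked out; their two values are simply as given.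

Compound 4, `C=C(CCC)C(=O)c1ccc(OCC(=O)OC)c(C)c1C`, is not yet measured. It stands to compound 3 as compound 2 stands to compound 1: the change is methyl in place of hydrogen on an oxygen next to a carbonyl group. The place of the change reads word for word the same in both pairs, so this is the same change, made once between the measured pair and again here, on a core that differs only by the chain change already described.

The expectation for compound 4 therefore rests on compound 3 at 19300 nM and on the measured step of a 1.7-fold lower number from compound 1 to compound 2 (0.22 log units; within the scatter): a step of about the same size, a 1.7-fold lower number from compound 3 to compound 4 (0.22 log units; within the scatter), is expected, with wide room either way because the measured step is itself within the scatter. Compound 4 is accordingly estimated at 11500 nM in this assay, with a likely range from 6000 nM to 22000 nM.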

Compound 4, concentration for 50% growth inhibition: 8600 nM
Estimate against measurement, compound 4: 1.3-fold (0.13 log units) above, within the range that was stated.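

In this assay, the change from carboxy to methoxycarbonyl on the core of compound 3 gives a 2.2-fold lower number from compound 3 to compound 4 (0.35 log units; beyond the scatter), while the chain change on the methoxycarbonyl core gives no change at the digits printed from compound 2 to compound 4 (within the scatter). Carboxy to methoxycarbonyl therefore carries from one core to the other without a measurable difference in step size, although only the step on the core of compound 3 lies beyond the scatter, and that only modestly: the same change on two cores in this assay, a 1.7-fold lower number (0.22 log units; within the scatter) from compound 1 to compound 2 and a 2.2-fold lower number (0.35 log units; beyond the scatter) from compound 3 to compound 4, 1.3-fold (0.13 log units) apart, within the scatter of two such steps. The chain change also reads alike on the carboxy and methoxycarbonyl compounds, but these two pairs on two closely related cores do not show that either step has a fixed size, or that it would hold on a core further removed: the same change on two cores in this assay, a 1.3-fold higher number (0.13 log units; within the scatter) from compound 1 to compound 3 and no change at the digits printed (within the scatter) from compound 2 to compound 4, 1.3-fold (0.13 log units) apart, within the scatter of two such steps.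

The compounds shown leave open whether the ester step holds with a longer chain in place of the two chains here, or with an ethyl ester or an amide in place of methoxycarbonyl. Also open, on these data alone, is how an amine or a nitrile in place of the carboxy group would read in this assay.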